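Methyl on the piperidine: a step expected within scatter

The compounds below may be only part of what the source reports. "The series", "measured", "known", "first", "only" and "open" are said of these compounds alone.

Measured compounds:
Compound 1, `COc1ccc(Nc2ncc3c(n2)N(C2CCCC2)CC(=O)N3C)cc1`: > 30000 nM
Compound 2, `CN1CCN(c2ccc(Nc3ncc4c(n3)N(C3CCCC3)CC(=O)N4)cc2)CC1`: 26100 nM
Compound 3, `O=C1CN(C2CCCC2)c2nc(Nc3ccc(N4CCCCC4)cc3)ncc2N1`: 25000 nM

In a functional assay on MDA-MB-231 cells (Homo sapiens) for inhibition, read by MTT assay, with a stated time of 48 h (a higher number here means a weaker inhibitor, a lower number a stronger inhibitor), compound 1 gives only a limit, > 30000 nM. Compound 2 gives 26100 nM in this assay. For the measured compounds named here, compound 3 gives 25000 nM in this assay, the lower of the two numbers, though its gap to compound 2 is within the scatter: the one measured step, a 1.0-fold lower number from compound 2 to compound 3 (0.02 log units; within the scatter), shows that exchanging the ring at the aromatic carbon moved the read-out not at all. Going by the values given here, the only other evidence is the limit of > 30000 nM in this assay, at which 1 of the 3 values shown sits, which places compound 1 outside the range of numbers.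

Compound 4, `CC1CCN(c2ccc(Nc3ncc4c(n3)N(C3CCCC3)CC(=O)N4)cc2)CC1`, is not yet measured. It differs from compound 3 by methyl in place of hydrogen on a saturated ring carbon. Among the compounds with values here, no measured step touches a substituent on this saturated ring; the nearest comparison, a 1.0-fold lower number from compound 2 to compound 3 (0.02 log units; within the scatter), swapped the whole ring without a change beyond the scatter. On that basis compound 4 is expected to show no step beyond the scatter, no change at the digits printed from compound 3 to compound 4 (within the scatter). The estimate for compound 4 in this assay is 25000 nM, with a range from 12000 nM to 50000 nM, and a real chance that only a limit is reported.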

Compound 4, half-maximal inhibitory concentration: 22700 nM
Beside the measured number, compound 4's estimate is 1.1-fold (0.04 log units) above it; measured number inside the range.
By their numbers in this assay, from the lowest: compounds 4, 3 and 2 (each within the scatter of the next). At a limit, above all of these: compound 1.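

In this assay, for the compounds shown here, this is the first reading of a substituent on the saturated ring itself, rather than an exchange of the whole ring, and the added methyl leaves the read-out within the scatter (a 1.1-fold lower number from compound 3 to compound 4 (0.04 log units; within the scatter)). The same holds against the piperazine-bearing comparison, where 4-methylpiperidin-1-yl replaces 4-methylpiperazin-1-yl on an aromatic carbon (a 1.1-fold lower number from compound 2 to compound 4 (0.06 log units; within the scatter)), so neither the ring exchange nor the methyl, three ring bonds from the ring nitrogen, has yet produced a step beyond the scatter among compound 2, compound 3 and compound 4. Nothing measured here accounts for this flat read-out.

The compounds shown leave open whether any group at this ring carbon can move the number beyond the scatter, since methyl is the only substituent tested there, and a longer chain such as n-butyl, a primary amine or a carboxylic acid at the same place would test that directly. They also leave open whether a methyl on another carbon of the piperidine ring would behave as this one does.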